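Swapping the Aryl Group on a Shared Core

The source may report more compounds than this note shows. Statements on the series, on what has been measured and on what is new or still open speak of the compounds shown alone.

Measured so far:
compound 1 `NC1=NC2(CCOCC2)N(OCCCOc2ccc(Cl)c(Cl)c2)C(N)=N1` — in an assay on isolated protein for inhibition of Dihydrofolate reductase (Homo sapiens), read by spectrophotometry, using NADPH, with stated times of 5 s and 6 min, tested at 50 uM (on this read-out higher numbers stand for a stronger effect at the one concentration tested and lower numbers for a weaker effect), compound 1 gives "not determined" (no result reported)
compound 2 `NC1=NC2(CCSCC2)N(OCCCOc2ccc(Br)cc2)C(N)=N1` — in this assay compound 2 gives "not determined" (no result reported)
compound 3 `NC1=NC2(CCSCC2)N(OCCCOc2cc(Cl)c(Cl)cc2Cl)C(N)=N1` — in this assay compound 3 gives 94.4%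

For the measured compounds named here, compound 1 has no number of its own yet; the only measured value in this set belongs to compound 3, whose inhibition in this assay is high. Compound 2 likewise stands without a result.

Compound 4 `Cc1cc(C)cc(OCCCON2C(N)=NC(N)=NC23CCOCC3)c1` is the next candidate. It differs from compound 1 in a single place: 3,5-dimethylphenyl in place of 3,4-dichlorophenyl on an oxygen on a saturated carbon. The remaining part of the molecule, the shared core with its two amino groups and the saturated ring containing oxygen, is kept.

Going by the values given here, there is no measured step from compound 1 to compound 4, so the size of the step cannot be read from the data. The one available figure, from compound 3, shows that a member of this series with a halogenated aryl group and a sulfur-containing ring can inhibit strongly at the tested concentration. Whether the dimethyl-substituted aryl group of compound 4 keeps that level is open.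

Compound 4 is expected to give about 70% in this assay, estimated within the range 35% to 95%.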

Compound 4, a percentage reported as inhibition, at one concentration (the size of the read-out at that concentration, not a potency): 88.6%
Estimate against measurement, compound 4: 18.6 percentage points below; the range from low to high includes it.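

No step can be read from compound 1 to compound 4: compound 4 gives 88.6% in this assay, while compound 1 has no result to set against it. The compounds shown leave open how 3,5-dimethylphenyl compares with 3,4-dichlorophenyl on this shared core. No measured evidence here offers an explanation for the result.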